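Fluoro in place of methoxy at an assay limit

The source may report more compounds than this note shows. Statements on the series, on what has been measured and on what is new or still open speak of the compounds shown alone.

In a functional assay on HepG2 cells (Homo sapiens) for antiproliferative activity, read by MTT assay, with a stated time of 72 h (on this read-out higher numbers stand for weaker inhibition and lower numbers for stronger inhibition), compound 1 `COc1cccc(N2C(=O)COc3ccc(-c4cnc5ccccc5c4)cc32)c1` gives 2080 nM. Compound 2 `COc1ccc(N2C(=O)COc3ccc(-c4cnc5ccccc5c4)cc32)cc1` reads > 40000 nM, which is a limit of the assay and not a number. Among the measured compounds shown here, the only measured step, an at least 19-fold higher number from compound 1 to compound 2 (1.28 log units; beyond the scatter), placed a methoxy where compound 3 `O=C1COc2ccc(-c3cnc4ccccc4c3)cc2N1c1ccc(F)cc1` carries its fluoro, and no step involving fluoro has been measured. The structural change is fluoro in place of methoxy on an aromatic carbon. A modest change toward lower numbers is therefore expected for compound 3 : an at least 2.0-fold lower number from compound 2 to compound 3 (0.30 log units; that floor lies within the scatter). Compound 3 is estimated at 20000 nM, with an expected range from 4000 nM to 40000 nM.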

Compound 3, half-maximal inhibitory concentration: 37200 nM
Compound 3: middle estimate off by 1.9-fold (0.27 log units), on the low side, within the range that was stated.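

Fluoro in place of methoxy gives an at least 1.0-fold lower number from compound 2 to compound 3 (0.03 log units; that floor lies within the scatter), so the size of this change stays unknown, because one end of the step is a limit and not a number: the limit of > 40000 nM in this assay, at which 1 of the 3 values shown sits.

Compound 3 does show that the weak result is not confined to 4-methoxyphenyl. The change from 3-methoxyphenyl to 4-fluorophenyl gives an 18-fold higher number from compound 1 to compound 3 (1.25 log units; beyond the scatter), so both compounds with a group in this place read far from compound 1 in this assay.

The compounds shown leave open how an amine or a carboxylic acid in place of the fluoro would read.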